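The compounds below may be only part of what the source reports. "The series", "measured", "known", "first", "only" and "open" are said of these compounds alone.

Series notes. In an ADME assay on RAW264.7 cells (Mus musculus) for cytotoxicity, read by neutral red uptake, with a stated time of 24 h (a lower number here means that less compound is tolerated, a higher number that more compound is tolerated), compound 1 (`O=C(CN1C(=O)S/C(=C\c2ccccc2)C1=O)NOCc1ccccc1`) gives > 128000 nM, a limit of the assay and not a number. Compound 2 (`O=C(CN1C(=O)S/C(=C\c2ccc(F)cc2)C1=O)NOCc1ccccc1`) gives > 128000 nM, also a limit and not a number. Within the data shown here, the only measured step, fluoro in place of hydrogen on an aromatic carbon, is a step that the two limits leave unreadable from compound 1 to compound 2. The evidence so far is the limit of > 128000 nM in this assay, at which 2 of the 2 values shown sit.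

The next change, (butyl in place of 4-fluorophenyl on a double-bonded chain carbon bound to a double-bonded ring carbon), leads to compound 3 (`CCCC/C=C1\SC(=O)N(CC(=O)NOCc2ccccc2)C1=O`), with butyl in place of 4-fluorophenyl on a double-bonded chain carbon bound to a double-bonded ring carbon. Among the measured compounds shown here, no measured step covers this exchange, and the one step available has no readable size. As far as these compounds go, no step beyond the scatter is therefore expected in this assay, though a move to a lower number remains open.

For compound 3 the expected value is 120000 nM, with an estimated range of 60000 nM to 240000 nM. The expected change is an at least 1.0-fold lower number from compound 2 to compound 3 (0.02 log units; that floor lies within the scatter).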

Compound 3, half-maximal cytotoxic concentration: > 128000 nM
Compound 3: only a limit was reported; the forecaster's own chance of this, stated with the estimate: 65%; middle value at least 1.0-fold (0.02 log units) from the limit.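

In this assay compound 3 gives > 128000 nM, a limit and not a number. Among these compounds, no step among compound 1, compound 2 and compound 3 can be read. The compounds shown leave open whether phenyl, 4-fluorophenyl and butyl differ at all in this read-out, and at what concentration any of them becomes cytotoxic.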